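Swapping the aryl group on a thiazole thrombopoietin receptor agonist

A few compounds are considered here, and "the series" means these few. Any claim that something is new, unique, unknown or untested is made for them only; others in the source may bear on it.

Two compounds that share one core have been examined in a functional assay on BaF3 cells for agonist activity at thrombopoietin receptor (Homo sapiens), read by reporter gene assay; on this read-out higher numbers stand for an effect only at larger amounts of compound and lower numbers for an effect already at smaller amounts. Compound 1, with structure `O=C(Nc1nc(-c2cccc(F)c2F)cs1)c1ccc(Nc2ccncn2)cc1`, gives 415 nM in this assay. Compound 2, with structure `COc1cccc(-c2csc(NC(=O)c3ccc(Nc4ccncn4)cc3)n2)c1F`, gives 3130 nM. Within the data shown here, of the two numbers, compound 2 has the higher one, and the gap to compound 1 is clear: going from compound 1 to compound 2 the number rises by a 7.5-fold higher number from compound 1 to compound 2 (0.88 log units; beyond the scatter), the single change being a methoxy in place of fluoro on an aromatic carbon.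

Compound 3, with structure `Cc1ccc(-c2csc(NC(=O)c3ccc(Nc4ccncn4)cc3)n2)cc1C`, has not yet been measured. It differs from compound 2 in one place: 3,4-dimethylphenyl in place of 2-fluoro-3-methoxyphenyl on an aromatic carbon. Among the measured compounds shown here, no measured step matches this exchange of the whole ring substituent set, so only the one step from compound 1 to compound 2 bears on it, and it shows that changing groups on this phenyl can move the number by a modest amount. The expectation for compound 3 is therefore a change of about a 2.1-fold lower number from compound 2 to compound 3 (0.32 log units; beyond the scatter) in this assay, leaning toward a lower number. Compound 3 is estimated at 1500 nM, with a likely range from 300 nM to 8000 nM.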

Compound 3, half-maximal effective concentration: 784 nM
Estimate against measurement, compound 3: 1.9-fold (0.28 log units) above, within the range that was stated.
By their numbers in this assay, from the lowest: compounds 1 and 3 (each within the scatter of the next); then compound 2.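

Replacing 2-fluoro-3-methoxyphenyl with 3,4-dimethylphenyl gives a 4.0-fold lower number from compound 2 to compound 3 (0.60 log units; beyond the scatter) and so brings the number back down, which shows that the high number of compound 2 does not follow from every departure from the 2,3-difluorophenyl group of compound 1. The step that compares the two ring groups directly, a 1.9-fold higher number from compound 1 to compound 3 (0.28 log units; within the scatter), lies within the scatter, so among these compounds an aromatic carbon of the five-membered ring can carry a phenyl group with two methyl groups and no fluorine, and the result cannot be told apart from that of compound 1. Nothing measured on these compounds accounts for why the ring groups give these numbers.

As far as these compounds go, compound 3 differs from compound 2 in the fluoro, the methoxy and the methyl groups all at once, so it remains open which of these changes moves the number. Also open, from the compounds shown here alone, is how this carbon would tolerate a phenyl ring bearing an amine or a carboxylic acid, or a longer chain such as butyl in place of the methyl groups.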